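Diethylamino for piperidin-1-yl on the side chain

The source may report more compounds than this note shows. Statements on the series, on what has been measured and on what is new or still open speak of the compounds shown alone.

In an ADME assay on L6 cells (Rattus norvegicus) for cytotoxicity, read by fluorescence, with a stated time of 72 h (a lower number here means a stronger inhibitor, a higher number a weaker inhibitor), compound 3 (`CN1CCN(C23CC(NC(=O)CCN4CCCCC4)C(C(c4ccccc4)C2)C(c2ccccc2)C3)CC1`) gives 15400 nM. That lies within the scatter of compound 2 (`CCN(CC)CC(=O)NC1CC2(N3CCN(C)CC3)CC(c3ccccc3)C1C(c1ccccc1)C2`) at 26400 nM, and modestly beyond it from compound 1 (`CN1CCN(C23CC(NC(=O)CCN4CCCC4)C(C(c4ccccc4)C2)C(c2ccccc2)C3)CC1`) at 42200 nM.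

Compound 4 (`CCN(CC)CCC(=O)NC1CC2(N3CCN(C)CC3)CC(c3ccccc3)C1C(c1ccccc1)C2`) carries diethylamino in place of piperidin-1-yl on a saturated chain carbon, two bonds along the chain from a carbonyl carbon.

For the measured compounds named here, two measured steps bear on this. At the same place, the pyrrolidin-1-yl to piperidin-1-yl change gave a 2.7-fold lower number from compound 1 to compound 3 (0.44 log units; beyond the scatter). Going by the values given here, the only measured diethylamino compound, with that group on a saturated chain carbon bound to a carbonyl carbon, enters through a 1.7-fold lower number from compound 2 to compound 3 (0.23 log units; within the scatter).

In this assay a small rise is expected, with an estimated size of a 1.6-fold higher number from compound 3 to compound 4 (0.19 log units; within the scatter), within the scatter. Compound 4 is expected at 24000 nM, with an estimated range of 11000 nM to 52000 nM.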

Compound 4, half-maximal inhibitory concentration: 35900 nM
Compound 4: the middle estimate sits 1.5-fold (0.17 log units) below what was measured; measured number inside the range.
By their numbers in this assay, from the lowest: compounds 3, 2, 4 and 1 (each within the scatter of the next, the first and the last beyond it).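

At this place, two bonds along the chain from a carbonyl carbon, diethylamino for piperidin-1-yl gives a 2.3-fold higher number from compound 3 to compound 4 (0.37 log units; beyond the scatter) in this assay, so among the three amines at this place, only piperidin-1-yl stands apart. Diethylamino for pyrrolidin-1-yl gives a 1.2-fold lower number from compound 1 to compound 4 (0.07 log units; within the scatter), while (diethylamino)methyl for diethylamino gives a 1.4-fold higher number from compound 2 to compound 4 (0.13 log units; within the scatter), and neither step separates its pair. No measurement available here accounts for these steps.

As far as these compounds go, whether a morpholin-4-yl group at this place would read with piperidin-1-yl or with the other two amines stays open. From the compounds shown here alone, the result of a longer chain between the carbonyl and the amine also stays open.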